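A few compounds are considered here, and "the series" means these few. Any claim that something is new, unique, unknown or untested is made for them only; others in the source may bear on it.

Compound 1 `CCOC(=O)c1cc(-c2cccc(OCc3cccc(C)c3)c2)on1` belongs to a small set of esters sharing one core and tested in an ADME assay on Vero cells (Chlorocebus sabaeus) for cytotoxicity, with a stated time of 72 h; on this read-out lower numbers stand for stronger inhibition and higher numbers for weaker inhibition. In this assay compound 1 gives only a limit, > 128000 nM, not a measured number. Compound 2 `CCOC(=O)c1cc(-c2cccc(OCc3ccc(F)cc3)c2)on1` carries the same core with a different benzyl-type group on the ether oxygen. In this assay, for the measured compounds named here, compound 2 is recorded as "not determined" (no result reported), so no single number places it; among the two compounds the only value shown is the limit of > 128000 nM in this assay, at which 1 of the 2 values shown sits, and compound 2 contributes nothing to that picture. Compound 3 `CCOC(=O)c1cc(-c2cccc(OCc3cc(F)cc(F)c3)c2)on1` is the next member, differing from compound 2 by 3,5-difluorophenyl in place of 4-fluorophenyl on a saturated chain carbon bound to an oxygen on an aromatic ring. Going by the values given here, with no measured step from one compound to another in this assay, no shift beyond the usual scatter is expected in either direction. Compound 3 is therefore expected to give about 150000 nM, with a range from 50000 nM to 500000 nM, most likely again reported only as a limit.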

Compound 3, half-maximal inhibitory concentration: > 128000 nM
Compound 3 was reported as a limit; the forecaster's own chance of this, stated with the estimate: 80%; the middle value is on the limit's open side.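

For the compounds shown here, compound 1 and compound 3 each give only a limit in this assay, not a number, so no step between them can be read: the limit of > 128000 nM in this assay, at which 2 of the 3 values shown sit. The compounds shown leave open where the true value of either compound lies, and whether exchanging these benzyl-type groups changes it at all.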